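From fluoro to bromo: a step not yet measured

This account rests on a few compounds, and the source may have more. Where it says the series, first, only, none or still open, it means among the compounds named here.

Of the compounds shown here, three sharing one core have so far been measured in a functional assay on HL-60 cells (Homo sapiens) for cytotoxicity, read by luminescence and CellTiter-Glo, with a stated time of 3 days (on this read-out higher numbers stand for weaker inhibition and lower numbers for stronger inhibition), and their numbers lie close together. There compound 1 (`O=C(Nc1ccc(OC(F)(F)F)cc1)c1cc(F)ccc1O`) gives 850 nM as its reading, compound 2 (`O=C(Nc1ccc(C(F)(F)F)cc1)c1cc(F)ccc1O`) gives 490 nM and compound 3 (`O=C(Nc1ccc([N+](=O)[O-])cc1)c1cc(F)ccc1O`) gives 520 nM on the same scale. Compound 2 therefore stands level with the other two, since all three values lie within the scatter of one another.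

Compound 4 (`O=C(Nc1ccc(C(F)(F)F)cc1)c1cc(Br)ccc1O`) departs from compound 2 in one place. The change is bromo in place of fluoro on an aromatic carbon and it amounts to bromo in place of fluoro on an aromatic carbon, para to a hydroxy group.

Among the compounds with values here, none of the measured steps touches the fluoro group. Trifluoromethyl for trifluoromethoxy gave a 1.7-fold lower number from compound 1 to compound 2 (0.24 log units; within the scatter) while nitro for trifluoromethoxy gave a 1.6-fold lower number from compound 1 to compound 3 (0.21 log units; within the scatter) and nitro for trifluoromethyl gave a 1.1-fold higher number from compound 2 to compound 3 (0.03 log units; within the scatter) in the same read-out. These steps bear on the new change only indirectly, and nothing measured sizes a swap of fluoro for bromo. No step beyond the scatter is therefore expected, and the estimate stays close to compound 2 at 490 nM as its starting point.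

The expected move is a 1.4-fold lower number from compound 2 to compound 4 (0.15 log units; within the scatter) and it remains only an estimate. Compound 4 is estimated at 350 nM in this assay with an expected range from 120 nM to 1000 nM for the coming measurement.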

Compound 4, half-maximal inhibitory concentration: 580 nM
The estimate for compound 4 lay 1.7-fold (0.22 log units) below the measured number, and the stated range covers the measured number.
By their numbers in this assay, from the lowest: compounds 2, 3, 4 and 1 (each within the scatter of the next).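

Within the data shown here, the first measured exchange at this position, bromo in place of fluoro on an aromatic carbon para to a hydroxy group, gives in this assay a 1.2-fold higher number from compound 2 to compound 4 (0.07 log units; within the scatter) and so leaves the reading within the scatter. Among these compounds, the earlier steps changed only the trifluoromethoxy, trifluoromethyl and nitro groups and left the fluoro group untouched, so this pair is the first to show that, with trifluoromethyl held constant, one halogen can take the place of the other without a step beyond the scatter. Nothing here accounts for that outcome, and no other kind of measurement bears on this pair of readings.

On these data alone, the result covers only two halogens at this position, so it remains open whether a chloro group, a methoxy group, an amine or a carboxylic acid placed there would also stay within the scatter of these readings. It also remains open whether the same exchange would read alike with trifluoromethoxy or nitro in place of trifluoromethyl, as the bromo group is shown here with trifluoromethyl alone.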